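Notes on the step from propanoyl to vinylcarbonyl

The source may report more compounds than this note shows. Statements on the series, on what has been measured and on what is new or still open speak of the compounds shown alone.

Measured in a functional assay on Raji cells (Homo sapiens) for inhibition, read by WST assay, with a stated time of 4 days; on this read-out higher numbers stand for weaker inhibition and lower numbers for stronger inhibition:
Compound 1 `CC(C)(C)c1ccc(CN2CCN(S(=O)(=O)Nc3ccc(SCCc4ccccc4)cc3C(=O)O)CC2)cc1`: 51500 nM
Compound 2 `CCC(=O)N1CCN(c2c3ccc(-c4cccc(F)c4)cc3nn2Cc2ccccc2)CC1`: 48200 nM

Compound 2, at 48200 nM, stands level with compound 1 within the usual scatter, so these numbers do not separate the two. Within the data shown here, their structures also differ too widely for a single-place comparison, and no step between measured compounds is available.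

Compound 3 `C=CC(=O)N1CCN(c2c3ccc(-c4cccc(F)c4)cc3nn2Cc2ccccc2)CC1` keeps the core of compound 2 and changes one group: vinyl in place of ethyl on a carbonyl carbon. The propanoyl becomes vinylcarbonyl, with vinyl in place of ethyl on a carbonyl carbon, and the 4-propanoylpiperazin-1-yl thus becomes 4-(vinylcarbonyl)piperazin-1-yl. Among the measured compounds shown here, no measured pair here shows this change, so the expectation is a judgement and carries a wide range. A moderate step toward stronger inhibition in this assay is expected, beyond the scatter, although a result within the scatter of compound 2 remains possible. The expected step runs a 3.2-fold lower number from compound 2 to compound 3 (0.51 log units; beyond the scatter). For compound 3 the estimated value is 15000 nM, with an expected range of 3000 nM to 60000 nM.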

Compound 3, half-maximal inhibitory concentration: 26900 nM
For compound 3 the middle estimate is 1.8-fold (0.25 log units) below the measured one; the range from low to high includes it.
By their numbers in this assay, from the lowest: compounds 3, 2 and 1 (each within the scatter of the next).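

In this assay the series now has its first single-place comparison: vinyl in place of ethyl on a carbonyl carbon gives a 1.8-fold lower number from compound 2 to compound 3 (0.25 log units; within the scatter) and so does not separate the two compounds on this read-out. At this place, on a carbonyl carbon whose other neighbour is an amide-type nitrogen in a ring, the added double bond outside aromatic rings therefore brings no change that can be told from the usual scatter of repeated measurements, and compound 1 is too different in structure to add to this comparison. No supporting measurement is available that would bear on this result.

Still open, going by these compounds, is whether a group of another kind on this carbonyl carbon, such as a longer chain like butyl, a dimethylaminomethyl-substituted vinyl or a carboxylic acid, would give a step beyond the scatter. The reading also rests on a single pair with the shared core of compound 2 and compound 3, so whether the same change reads alike on a different core remains unsettled.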